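Swapping the amide substituent: from cyano to methoxy

The compounds below may be only part of what the source reports. "The series", "measured", "known", "first", "only" and "open" are said of these compounds alone.

Among the compounds with values here, compound 3 `COc1cc2oc(-c3cccc(NC(=O)c4ccc(C#N)cc4)c3)cc(=O)c2c(OC)c1OC` gives 10200 nM in a functional assay on HepG2 cells (Homo sapiens) for inhibition, read by MTT assay (on this read-out higher numbers stand for weaker inhibition of growth and lower numbers for stronger inhibition of growth), the second highest of the three numbers measured so far. Its nearest neighbour is compound 1 `COc1cc2oc(-c3cccc(NC(=O)c4ccc(Br)cc4)c3)cc(=O)c2c(OC)c1OC` with 8850 nM, and a 1.2-fold higher number from compound 1 to compound 3 (0.06 log units; within the scatter). Compound 2 `COc1cc2oc(-c3cccc(NC(=O)c4ccc(F)cc4)c3)cc(=O)c2c(OC)c1OC` lies furthest with 47200 nM, and a 4.6-fold lower number from compound 2 to compound 3 (0.67 log units; beyond the scatter). Compound 4 `COc1cccc(C(=O)Nc2cccc(-c3cc(=O)c4c(OC)c(OC)c(OC)cc4o3)c2)c1` is not yet measured; it differs from compound 3 by 3-methoxyphenyl in place of 4-cyanophenyl on a carbonyl carbon. The measured steps only compare bromo, fluoro and cyano on that ring, none of them a methoxy, so they set no direction; they show that changes on this ring have moved the number modestly at most. Compound 4 is therefore expected to stay close, with a 1.5-fold higher number from compound 3 to compound 4 (0.17 log units; within the scatter), estimated at 15000 nM (range 5000 nM to 50000 nM).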

Compound 4, concentration for 50% growth inhibition: 7060 nM
The estimate for compound 4 lay 2.1-fold (0.33 log units) above the measured number, within the range that was stated.
By their numbers in this assay, from the lowest: compounds 4, 1 and 3 (each within the scatter of the next); then compound 2.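

In this assay, swapping to 3-methoxyphenyl on the carbonyl carbon leaves the number level with the 4-cyanophenyl and 4-bromophenyl amides (a 1.4-fold lower number from compound 3 to compound 4 (0.16 log units; within the scatter); a 1.3-fold lower number from compound 1 to compound 4 (0.10 log units; within the scatter)). It stands clearly apart only from the 4-fluorophenyl amide (a 6.7-fold lower number from compound 2 to compound 4 (0.83 log units; beyond the scatter)), so a methoxy group, in a different ring location, fits the level of nitrile and bromo, and compound 2 remains the one exception among the four. Nothing available here explains this difference. Still open, on these data alone, is whether 4-methoxyphenyl would match 3-methoxyphenyl, and whether an amine or a carboxylic acid on this ring would keep the same level.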